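Swapping the Sulfonyl Aryl Group in Compound 3

A few compounds are considered here, and "the series" means these few. Any claim that something is new, unique, unknown or untested is made for them only; others in the source may bear on it.

Three compounds have been measured in a functional assay on COLO 205 cells (Homo sapiens) for cytotoxicity, read by MTT assay, with a stated time of 24 h; a higher number here means a weaker inhibitor, a lower number a stronger inhibitor:

Compound 1 `COc1cc2nc(N3CCCC3)nc(NS(=O)(=O)c3ccc(C)cc3)c2cc1OC` gives 24.1 ug/mL
Compound 2 `COc1ccc(S(=O)(=O)Nc2nc(Cl)nc3cc(OC)c(OC)cc23)cc1C` gives 57 ug/mL
Compound 3 `COc1cc2nc(Cl)nc(NS(=O)(=O)c3ccc(C)cc3)c2cc1OC` gives 91.3 ug/mL

Compound 3 carries the highest number of the three. The gap a 1.6-fold higher number from compound 2 to compound 3 (0.20 log units; within the scatter) stays within the scatter, whereas a 3.8-fold higher number from compound 1 to compound 3 (0.58 log units; beyond the scatter) lies beyond it.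

Compound 4 `COc1cc2nc(Cl)nc(NS(=O)(=O)c3cccs3)c2cc1OC` differs from compound 3 in one place: thiophen-2-yl in place of 4-methylphenyl on a sulfonyl sulfur. Going by the values given here, only one measured step touches the same place, the group on the sulfonyl sulfur: a 1.6-fold higher number from compound 2 to compound 3 (0.20 log units; within the scatter), which stayed within the scatter. The step of a 3.8-fold higher number from compound 1 to compound 3 (0.58 log units; beyond the scatter) concerns another place and does not bear on this swap. A small step, within the scatter, is therefore expected: a 1.1-fold lower number from compound 3 to compound 4 (0.06 log units; within the scatter). Compound 4 is expected to give 80 ug/mL, ranging from 30 ug/mL to 200 ug/mL.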

Compound 4, half-maximal inhibitory concentration: 27.5 ug/mL
Compound 4: middle estimate off by 2.9-fold (0.46 log units), on the high side; the whole stated range lies above it.
By their numbers in this assay, from the lowest: compounds 1 and 4 (each within the scatter of the next); then compounds 2 and 3 (each within the scatter of the next).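

The group on the sulfonyl sulfur can matter in this assay after all: thiophen-2-yl in place of 4-methylphenyl gives a clear shift (a 3.3-fold lower number from compound 3 to compound 4 (0.52 log units; beyond the scatter)), and thiophen-2-yl in place of 4-methoxy-3-methylphenyl gives another (a 2.1-fold lower number from compound 2 to compound 4 (0.32 log units; beyond the scatter)). The earlier step at this place stayed within the scatter, so only the swap to the five-membered ring containing sulfur has moved the number beyond it. Nothing measured here explains the shift.

Still open, as far as these compounds go, is whether furan-2-yl or a simple methyl on the sulfonyl sulfur would behave the same way, and whether thiophen-2-yl would give a similar step alongside the pyrrolidin-1-yl of compound 1.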